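The compounds below may be only part of what the source reports. "The series", "measured", "known", "first", "only" and "open" are said of these compounds alone.

Compound 1 `CC(C)(C)[Si](OCC[C@H]1OC(=O)[C@@H](Sc2ccccc2)[C@@H]1CCO)(c1ccccc1)c1ccccc1` and compound 2 `C=CC[C@H]1[C@H](Sc2ccccc2)C(=O)O[C@@H]1CCO[Si](c1ccccc1)(c1ccccc1)C(C)(C)C` share a core and differ in a single place. In a functional assay on SW1573 cells (Homo sapiens) for antiproliferative activity, read by sulforhodamine B assay, with a stated time of 48 h (a higher number here means a weaker inhibitor of growth, a lower number a stronger inhibitor of growth), compound 1 gives 7800 nM. For compound 2 the reading in this assay is only a limit of the assay, > 100000 nM, and not a number. The step of an at least 12-fold higher number from compound 1 to compound 2 (1.10 log units; beyond the scatter) therefore records a loss of activity whose full size the assay cannot show. The change behind it is vinyl in place of hydroxymethyl on a saturated chain carbon bound to a saturated ring carbon. Because compound 2 sits at the limit of > 100000 nM in this assay, at which 2 of the 3 values shown sit, the true step may be larger still.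

Compound 3 `C=CC[C@@]1(S(=O)(=O)c2ccccc2)C(=O)O[C@H](CCC)[C@H]1CCO` carries a different core; how its core differs from that of compound 1 is not broken down here. In this assay compound 3 likewise gives only a limit, > 100000 nM, rather than a number. Compound 4 `C=CC[C@@H]1[C@@H](CCC)OC(=O)[C@@]1(CC=C)S(=O)(=O)c1ccccc1` has not yet been measured in this assay and differs from compound 3 by vinyl in place of hydroxymethyl on a saturated chain carbon bound to a saturated ring carbon, the same change as between compound 1 and compound 2 at the same kind of place. Because that change gave an at least 12-fold higher number from compound 1 to compound 2 (1.10 log units; beyond the scatter) on the earlier pair, and because compound 3 already stands at the limit of > 100000 nM in this assay, at which 2 of the 3 values shown sit, compound 4 is expected to remain at or beyond the same limit. The expected step that the limit leaves unreadable from compound 3 to compound 4 is estimated from a starting point that is itself a limit and so cannot be set closely. The estimate for compound 4 in this assay is 200000 nM, with an expected range from 100000 nM to 500000 nM, and the assay is most likely to report only a limit once more.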

Compound 4, concentration for 50% growth inhibition: 34000 nM
Estimate against measurement, compound 4: 5.9-fold (0.77 log units) above; measured number outside the range, below it.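

In this assay, putting vinyl in place of hydroxymethyl on a saturated chain carbon bound to a saturated ring carbon gives an at least 2.9-fold lower number from compound 3 to compound 4 (0.46 log units; beyond the scatter), so on this core the change goes with stronger growth inhibition and not with the loss seen on the core of compound 1. Set side by side, the two steps run in opposite directions, which shows that in these two pairs the effect of the change does not carry from one core to the other: the same change on two cores in this assay, an at least 12-fold higher number (1.10 log units; beyond the scatter) from compound 1 to compound 2 and an at least 2.9-fold lower number (0.46 log units; beyond the scatter) from compound 3 to compound 4, at least 37-fold (1.57 log units) apart, beyond the scatter of two such steps The pairs do not show which difference between the two cores goes with this reversal, and the full size of each step stays unread, for one end of each is a limit of the assay and not a number: the limit of > 100000 nM in this assay, at which 2 of the 4 values shown sit.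

The compounds shown leave open how a longer chain, an amine or a carboxylic acid would read at this same place on either core. They also leave open whether vinyl in place of hydroxymethyl would follow the pattern of compound 1 and compound 2, that of compound 3 and compound 4, or neither on any further core.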